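The source may report more compounds than this note shows. Statements on the series, on what has been measured and on what is new or still open speak of the compounds shown alone.

Of the compounds shown here, three have numbers so far in a functional assay on MIA PaCa-2 cells (Homo sapiens) for inhibition, read by MTT assay, with a stated time of 48 h, tested at 10 uM; a higher number here means more inhibition of growth at the concentration tested, a lower number less inhibition of growth. Compound 1 `Cc1cc(=O)c2c(O)cc(OCc3ccccc3Br)c([C@H]3CCN(C)C[C@H]3O)c2o1` gives 30%, compound 2 `Cc1cc(=O)c2c(O)c(CN3CCC(c4ccccc4)CC3)c(O)c([C@H]3CCN(C)C[C@H]3O)c2o1` gives 16%, and compound 3 `Cc1oc2c([C@H]3CCN(C)C[C@H]3O)c(O)cc(O)c2c(=O)c1C(O)c1ccccc1Br` gives 10%. Compound 3 stands at the low end of this small set, within the scatter of compound 2 and beyond the scatter under compound 1. Compound 4 `CCOc1ccc(Br)c(C(O)c2c(C)oc3c([C@H]4CCN(C)C[C@H]4O)c(O)cc(O)c3c2=O)c1` has ethoxy in place of hydrogen on an aromatic carbon, para to a bromo group, so 2-bromophenyl becomes 2-bromo-5-ethoxyphenyl: ethoxy in place of hydrogen on an aromatic carbon. Within the data shown here, no measured pair isolates this change, so the data offer no direct guide. In this assay, the expected step is small and upward, within the scatter: a number 4 percentage points higher from compound 3 to compound 4 (within the scatter). Compound 4 is estimated at 14%, with an expected range of 3% to 30%.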

Compound 4, percent growth inhibition at one concentration: 4%
Estimate against measurement, compound 4: 10 percentage points above, and the stated range covers the measured number.
By their numbers in this assay, from the lowest: compounds 4, 3 and 2 (each within the scatter of the next, the first and the last beyond it); then compound 1.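

Ethoxy in place of hydrogen on an aromatic carbon, meta to a large group and para to a bromo group, gives a number 6 percentage points lower from compound 3 to compound 4 (within the scatter) in this assay. Among these compounds, this is the first single-place step, and at this one concentration it does not separate the 2-bromo-5-ethoxyphenyl compound from its 2-bromophenyl parent. The data offer no measured basis for explaining this result. Still open, on these data alone, is whether an amine, a carboxylic acid or a longer chain on this aromatic carbon would read differently from ethoxy. Also open, as far as these compounds go, is how ethoxy behaves on a ring without the bromo group.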